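Ethoxy for methoxy on the core of compound 2

The compounds below may be only part of what the source reports. "The series", "measured", "known", "first", "only" and "open" are said of these compounds alone.

Of the compounds shown here, two have been measured so far. Compound 2 `COc1nc(-c2cc3ccccc3o2)cc(-c2ccc(N(C)C)cc2)c1C#N` in a functional assay on aorta (strain Wistar) for inhibition, with Thoracic aorta (Rattus norvegicus) as the target (on this read-out lower numbers stand for stronger inhibition and higher numbers for weaker inhibition), gives 278000 nM. Compound 1 `CCOc1nc(-c2cc3ccccc3o2)cc(-c2ccc(OC)cc2OC)c1C#N` in this assay gives 488000 nM; the gap between compound 1 and compound 2 lies within the scatter of repeated measurements, so the two cannot be told apart on this read-out. Compound 3 `CCOc1nc(-c2cc3ccccc3o2)cc(-c2ccc(N(C)C)cc2)c1C#N` has not been measured. It differs from compound 2 by methyl in place of hydrogen on a saturated chain carbon bound to an oxygen on an aromatic ring, in words methyl in place of hydrogen on a saturated chain carbon bound to an oxygen on an aromatic ring, so that methoxy becomes ethoxy. Within the data shown here, no pair of measured compounds shows this change alone; compound 1 carries the ethoxy but differs from compound 2 elsewhere as well, so its value does not isolate the step. The step from compound 2 to compound 3 is expected to stay within the scatter, with no direction assigned: a 1.1-fold higher number from compound 2 to compound 3 (0.03 log units; within the scatter). Compound 3 is expected to give about 300000 nM in this assay, within a range from 100000 nM to 900000 nM.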

Compound 3, half-maximal inhibitory concentration: 338000 nM
Beside the measured number, compound 3's estimate is 1.1-fold (0.05 log units) below it, and the stated range covers the measured number.
By their numbers in this assay, from the lowest: compounds 2, 3 and 1 (each within the scatter of the next).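

In this assay, the change from methoxy to ethoxy can now be read alone: a 1.2-fold higher number from compound 2 to compound 3 (0.08 log units; within the scatter) shows that methyl in place of hydrogen on a saturated chain carbon bound to an oxygen on an aromatic ring gives no separable difference on this read-out. With ethoxy held constant, the aryl group can also be read alone, and 4-(dimethylamino)phenyl in place of 2,4-dimethoxyphenyl on an aromatic carbon gives a 1.4-fold lower number from compound 1 to compound 3 (0.16 log units; within the scatter) with no separable difference either. Nothing available bears on why these two steps stay so small.

Still open, as far as these compounds go, is whether a longer chain such as propoxy, or an amine in place of the ethoxy, would separate from these compounds. From the compounds shown here alone, a carboxylic acid in place of 4-(dimethylamino)phenyl is equally open.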